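Halogen Change on the Benzyl Ring and Growth Inhibition

The compounds below may be only part of what the source reports. "The series", "measured", "known", "first", "only" and "open" are said of these compounds alone.

The measured compounds:
compound 1, `Ic1ccc(Cn2cc(CCCOc3cccc4cccnc34)nn2)cc1`, > 250 ug/mL
compound 2, `Fc1ccc(Cn2cc(CCCOc3cccc4cccnc34)nn2)cc1`, 49.4 ug/mL
compound 3, `Clc1ccc(Cn2cc(CCCOc3cccc4cccnc34)nn2)cc1`, 11.6 ug/mL

In a functional assay on NCI/ADR-RES cells (Homo sapiens) for inhibition, read by sulforhodamine B assay, with a stated time of 48 h (a higher number here means a weaker inhibitor of growth, a lower number a stronger inhibitor of growth), compound 1 gives only a limit, > 250 ug/mL, which marks the edge of the assay (the limit of > 250 ug/mL in this assay, at which 1 of the 3 values shown sits). Among the two numbers that are not limits, compound 2 has the highest, and its nearest neighbour is compound 3, reached by a 4.3-fold lower number from compound 2 to compound 3 (0.63 log units; beyond the scatter). From compound 1 the changes run an at least 5.0-fold lower number from compound 1 to compound 2 (0.70 log units; beyond the scatter) and an at least 21-fold lower number from compound 1 to compound 3 (1.33 log units; beyond the scatter), so chloro at this position goes with a lower number than fluoro, and iodo with the limit.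

Compound 4, `Clc1cc(Cl)c(Cn2cc(CCCOc3cccc4cccnc34)nn2)c(Cl)c1`, has not yet been measured. It differs from compound 2 as follows: 2,4,6-trichlorophenyl in place of 4-fluorophenyl on a saturated chain carbon bound to an aromatic nitrogen. The step from compound 2 to compound 3 bears most directly on this change, since it also puts chloro in place of fluoro on an aromatic carbon, and it was modest. For the measured compounds named here, compound 4 carries three chloro groups rather than one, and no measured step tells how the two further chloro groups act, so the expectation rests on the single chloro step. For compound 4 a modest step toward a lower number is expected, a 4.1-fold lower number from compound 2 to compound 4 (0.61 log units; beyond the scatter), giving an estimate of 12 ug/mL with a range from 3 ug/mL to 45 ug/mL.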

Compound 4, concentration for 50% growth inhibition: 2.8 ug/mL
Beside the measured number, compound 4's estimate is 4.3-fold (0.63 log units) above it; measured number outside the range, below it.
By their numbers in this assay, from the lowest: compound 4; then compound 3; then compound 2. At a limit, above all of these: compound 1.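

In this assay, for the compounds shown here, the 2,4,6-trichlorophenyl group goes further than the single chloro of compound 3, with a 4.1-fold lower number from compound 3 to compound 4 (0.62 log units; beyond the scatter), and the full change from the fluoro compound amounts to an 18-fold lower number from compound 2 to compound 4 (1.25 log units; beyond the scatter), so this place still responds to further chloro groups, which the earlier compounds could not show. Compound 1 gives a limit and not a number: the limit of > 250 ug/mL in this assay, at which 1 of the 4 values shown sits. The step to the trichloro compound is therefore only a bound, an at least 89-fold lower number from compound 1 to compound 4 (1.95 log units; beyond the scatter).

The compounds shown leave open whether both further chloro groups contribute to the lower number or one of them accounts for most of it. Also open, from the compounds shown here alone, is how a methoxy or trifluoromethyl group would read in this assay on this phenyl ring in place of the halogens.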